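Sulfamoylamino Piperidinyl Pyrimidines: Chain Length and Growth Inhibition

A few compounds are considered here, and "the series" means these few. Any claim that something is new, unique, unknown or untested is made for them only; others in the source may bear on it.

The measured compounds and their values:
compound 1, `Cc1ccc(-c2cc(N3CCC(CNS(N)(=O)=O)CC3)ncn2)cc1`, 30600 nM
compound 2, `CCCCc1ccc(-c2cc(N3CCC(CNS(N)(=O)=O)CC3)ncn2)cc1`, 21800 nM
compound 3, `Cc1ccc(-c2cc(N3CCC(CCNS(N)(=O)=O)CC3)ncn2)cc1`, 47500 nM

These three compounds were examined in a functional assay on MCF7 cells (Homo sapiens) for antiproliferative activity, read by sulforhodamine B assay, with a stated time of 48 h; a higher number here means a weaker inhibitor of growth, a lower number a stronger inhibitor of growth. Compound 1 gives 30600 nM. Compound 2 carries the change (propyl in place of hydrogen on a saturated chain carbon bound to an aromatic carbon), and the step is a 1.4-fold lower number from compound 1 to compound 2 (0.15 log units; within the scatter). Compound 3 differs from compound 1 by (sulfamoylamino)methyl in place of sulfamoylamino on a saturated chain carbon bound to a saturated ring carbon, and here the step is a 1.6-fold higher number from compound 1 to compound 3 (0.19 log units; within the scatter). Compound 3 gives 47500 nM, while compound 2 gives 21800 nM.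

Compound 4, `CCCCc1ccc(-c2cc(N3CCC(CCNS(N)(=O)=O)CC3)ncn2)cc1`, has not been measured. Among the compounds with values here, it stands to compound 3 as compound 2 stands to compound 1: the change is propyl in place of hydrogen on a saturated chain carbon bound to an aromatic carbon, the same change as the one from compound 1 to compound 2, at a place described in identical words. The core of compound 3 and compound 4 differs from that of compound 1 and compound 2 by (sulfamoylamino)methyl in place of sulfamoylamino on a saturated chain carbon bound to a saturated ring carbon.

The step from compound 3 to compound 4 in this assay is expected to be a 1.4-fold lower number from compound 3 to compound 4 (0.16 log units; within the scatter), close to the earlier one, because it rests on a 1.4-fold lower number from compound 1 to compound 2 (0.15 log units; within the scatter). Compound 4 is therefore estimated at 33000 nM, between 16000 nM and 70000 nM.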

Compound 4, concentration for 50% growth inhibition: 11300 nM
Compound 4: the middle estimate sits 2.9-fold (0.47 log units) above what was measured; the whole stated range lies above it.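

In this assay, propyl in place of hydrogen gives a 4.2-fold lower number from compound 3 to compound 4 (0.62 log units; beyond the scatter), so on the core of compound 3 this change did not keep the size it had on the core of compound 1: the same change on two cores in this assay, a 1.4-fold lower number (0.15 log units; within the scatter) from compound 1 to compound 2 and a 4.2-fold lower number (0.62 log units; beyond the scatter) from compound 3 to compound 4, 3.0-fold (0.48 log units) apart, beyond the scatter of two such steps Read the other way, (sulfamoylamino)methyl in place of sulfamoylamino gives a 1.9-fold lower number from compound 2 to compound 4 (0.29 log units; within the scatter), and although this step and its counterpart on the core of compound 1 each lie within the scatter, they still stand apart: the same change on two cores in this assay, a 1.6-fold higher number (0.19 log units; within the scatter) from compound 1 to compound 3 and a 1.9-fold lower number (0.29 log units; within the scatter) from compound 2 to compound 4, 3.0-fold (0.48 log units) apart, beyond the scatter of two such steps In these four compounds, then, the two changes do not simply add, and a step read on one core did not carry over to the other, but the data do not show why this happens or whether it would hold on any further core.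

As far as these compounds go, whether a longer chain than butyl, or an amine in its place, would go further than compound 4 stays open. So does whether a longer chain carrying the sulfamoylamino group would widen the gap between the two cores.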